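This account rests on a few compounds, and the source may have more. Where it says the series, first, only, none or still open, it means among the compounds named here.

Of the compounds shown here, two carry numbers so far. In a functional assay on HL-60 cells (Homo sapiens) for antiproliferative activity, read by sulforhodamine B assay, with a stated time of 72 h (a higher number here means a weaker inhibitor, a lower number a stronger inhibitor), compound 1 `CN(C)C(=S)N/N=C/c1ccc2ccccc2n1` gives 50 nM, while compound 2 `FC(F)(F)c1ccccc1NC(=S)N/N=C/c1ccc2ccccc2n1` gives 13200 nM. Compound 2 thus holds the highest number of the two, and the gap to compound 1 lies well beyond the usual scatter. The two differ in more than one place, so the gap cannot be pinned to a single change.

The step now followed leads from compound 2 to compound 3 `Cc1ccccc1NC(=S)N/N=C/c1ccc2ccccc2n1`. The change is methyl in place of trifluoromethyl on an aromatic carbon; it stays on the aromatic ring and alters no donor or acceptor count.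

Going by the values given here, no measured step of this kind stands, so the expectation rests on little. The step from compound 2 to compound 3 is expected to be modest and to run toward a lower number, a 3.3-fold lower number from compound 2 to compound 3 (0.52 log units; beyond the scatter), though a step within the scatter would not surprise. For compound 3 in this assay the estimate is 4000 nM, with a range from 800 nM to 20000 nM.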

Compound 3, half-maximal inhibitory concentration: 73200 nM
Compound 3: the middle estimate sits 18-fold (1.26 log units) below what was measured; measured number above the stated range.
By their numbers in this assay, from the lowest: compound 1; then compound 2; then compound 3.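

In this assay, going by these compounds alone, the change from trifluoromethyl to methyl, on an aromatic carbon ortho to a large group, gives a 5.5-fold higher number from compound 2 to compound 3 (0.74 log units; beyond the scatter) and is the first step that differs in one place only. It shows that the number at this position responds to the group carried there, and that, of these two groups, trifluoromethyl goes with the lower number.

As far as these compounds go, whether a chlorine, a methoxy group or a plain hydrogen on this carbon would lie nearer compound 2 or compound 3 stays open. Also open, from the compounds shown here alone, is whether the same exchange on another carbon of the aromatic ring would move the number the same way.

No measurement shown here accounts for this step.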